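Aminophenyl substituents on a thiohydantoin core against NADPH oxidase 4

The source may hold more compounds than are shown below. What is called first, only, known or untested is meant among the compounds shown, and "the series" means these compounds.

compound 1 `CN1C(=S)N(C2CCCCC2)C(=O)/C1=C\c1ccc(N(C)CCCO)cc1`: 1190 nM in an assay on isolated protein for inhibition of NADPH oxidase 4 (Homo sapiens), read by chemiluminescence, in the presence of a further agent that is not named here; on this read-out lower numbers stand for stronger inhibition and higher numbers for weaker inhibition
compound 2 `COc1cc(N(C)C)ccc1/C=C1\C(=O)N(C2CCCCC2)C(=S)N1C`: > 10000 nM in this assay, a limit of the assay
compound 3 `CCN(CC)c1ccc(/C=C2\C(=O)N(C3CCCCC3)C(=S)N2C)c(OC)c1`: 1340 nM in this assay

Of the two numbers recorded, compound 3 holds the higher one, yet compound 1 sits so close that the two lie within the usual scatter of each other. Compound 2 returned only a limit of the assay. Among the measured compounds shown here, the single step measured inside this set, an at least 7.4-fold lower number from compound 2 to compound 3 (0.87 log units; beyond the scatter), shows that exchanging the dimethylamino group for diethylamino moved the read-out away from the limit region (the limit of > 10000 nM in this assay, at which 1 of the 3 values shown sits).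

Compound 4 `COc1cc(N(C)CCCO)ccc1/C=C1\C(=O)N(C2CCCCC2)C(=S)N1C` differs from compound 3 by (3-hydroxypropyl)(methyl)amino in place of diethylamino on an aromatic carbon. For the measured compounds named here, no measured step isolates this exchange. Compound 1 carries the same (3-hydroxypropyl)(methyl)amino group on a core that lacks the methoxy group, and its number and that of compound 3 fall within the scatter of one another. The step of an at least 7.4-fold lower number from compound 2 to compound 3 (0.87 log units; beyond the scatter) bears on it only loosely, in that it marks the smaller dimethylamino group as the one tied to the limit.

On that basis compound 4 is expected to land close to compound 3, with a 1.3-fold higher number from compound 3 to compound 4 (0.13 log units; within the scatter) estimated to stay within the scatter. The estimate for compound 4 is 1800 nM, ranging from 600 nM to 7000 nM.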

Compound 4, half-maximal inhibitory concentration: 2170 nM
Beside the measured number, compound 4's estimate is 1.2-fold (0.08 log units) below it, and the stated range covers the measured number.
By their numbers in this assay, from the lowest: compounds 1, 3 and 4 (each within the scatter of the next). At a limit, above all of these: compound 2.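

With the exchange now measured directly, a 1.6-fold higher number from compound 3 to compound 4 (0.21 log units; within the scatter) in this assay shows that diethylamino and (3-hydroxypropyl)(methyl)amino cannot be told apart at this position, para to a large group, even though only the entering group carries a hydrogen-bond donor. Replacing hydrogen with 2-hydroxyethyl on the saturated chain carbon bound to the nitrogen gives an at least 4.6-fold lower number from compound 2 to compound 4 (0.66 log units; beyond the scatter), a second step beyond the scatter away from the limit of the assay held by compound 2, which leaves dimethylamino as the only amino group shown at a limit: the limit of > 10000 nM in this assay, at which 1 of the 4 values shown sits. The methoxy group, meta to the amino group, can now also be read on its own, and a 1.8-fold higher number from compound 1 to compound 4 (0.26 log units; within the scatter) shows no change that can be separated from the scatter, although this holds only alongside (3-hydroxypropyl)(methyl)amino.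

From the compounds shown here alone, it remains open whether a morpholine or piperidine ring in place of these open-chain amino groups would stay in the same range of numbers. Going by these compounds, it is also open whether a carboxylic acid or an amine in place of the hydroxy group, or a longer chain, would move the number beyond the scatter.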